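Arene substituent swap: chloro replaced by nitro

The source may hold more compounds than are shown below. What is called first, only, known or untested is meant among the compounds shown, and "the series" means these compounds.

Compound 1 `CC1=CC[C@H](C(C)(C)NC(=S)N/N=C/c2ccccc2O)CC1` and compound 2 `CC1=CC[C@H](C(C)(C)NC(=S)N/N=C/c2ccccc2Cl)CC1` share one core and differ only in the group on the aromatic carbon. Within the data shown here, in a functional assay on U-251 cells (Homo sapiens) for inhibition, read by sulforhodamine B assay, with a stated time of 48 h (on this read-out higher numbers stand for weaker inhibition of growth and lower numbers for stronger inhibition of growth), compound 1 gives 6400 nM, and compound 2 gives 80600 nM; the step of a 13-fold higher number from compound 1 to compound 2 (1.10 log units; beyond the scatter) is the only measured step in the set. Compound 2 therefore stands with the highest number of the two, the nearest neighbour being compound 1.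

Compound 3 `CC1=CC[C@H](C(C)(C)NC(=S)N/N=C/c2ccccc2[N+](=O)[O-])CC1` is the next member: nitro in place of chloro on an aromatic carbon, on an aromatic carbon of a six-membered aromatic ring of carbon only, ortho to a large group. Among the measured compounds shown here, no measured step exchanges chloro for nitro. For the measured compounds named here, the one step on record, a 13-fold higher number from compound 1 to compound 2 (1.10 log units; beyond the scatter), concerns hydroxy against chloro and shows that this position can move the number by a large amount, but it gives no direction for the present change. For compound 3 the expected step of a 1.3-fold lower number from compound 2 to compound 3 (0.13 log units; within the scatter) in this assay is taken as not beyond the scatter, with wide uncertainty. Compound 3 is estimated at 60000 nM, with a range from 15000 nM to 200000 nM.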

Compound 3, concentration for 50% growth inhibition: 20200 nM
Compound 3: the middle estimate sits 3.0-fold (0.47 log units) above what was measured, within the range that was stated.
By their numbers in this assay, from the lowest: compound 1; then compound 3; then compound 2.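

In this assay the exchange now has a direction of its own: a 4.0-fold lower number from compound 2 to compound 3 (0.60 log units; beyond the scatter) shows that nitro on this aromatic carbon gives stronger inhibition of growth than chloro, which the hydroxy-to-chloro step alone could not show. Nitro does not match hydroxy, however, as a 3.2-fold higher number from compound 1 to compound 3 (0.50 log units; beyond the scatter) stands beyond the scatter as well, so the position gives a graded order rather than a split between hydroxy and everything else: hydroxy in compound 1 gives the lowest number, nitro in compound 3 the middle one and chloro in compound 2 the highest. With only these three groups this order is a ranking and nothing more, and no measurement at hand explains it.

As far as these compounds go, how an amine, a carboxylic acid or a methoxy group on the same carbon would fall relative to hydroxy, nitro and chloro remains open. Also open, from the compounds shown here alone, is whether the same order holds with these groups elsewhere on the aromatic ring, or with changes to the rest of the shared core.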